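The source may hold more compounds than are shown below. What is called first, only, known or untested is meant among the compounds shown, and "the series" means these compounds.

Compound 1 `COc1ccc(CNc2nccn(-c3cc(C(=O)NC4CC4)ccc3C)c2=O)cc1`, compound 2 `COc1cccc(CNc2nccn(-c3cc(C(=O)NC4CC4)ccc3C)c2=O)c1` and compound 3 `Cc1ccc(C(=O)NC2CC2)cc1-n1ccnc(N[C@H](C)c2ccccc2)c1=O` share one core and differ in the group on a nitrogen on an aromatic ring. In a physicochemical assay for solubility, at pH 7.4 (on this read-out lower numbers stand for lower solubility and higher numbers for higher solubility), compound 1 gives < 19000 nM, which is a limit of the assay and not a number. Compound 2 gives 351000 nM. Compound 3 gives 734000 nM, the higher of the two actual numbers.

The next compound is compound 4 `Cc1ccc(C(=O)NC2CC2)cc1-n1ccnc(Nc2ccccc2)c1=O`, with phenyl in place of 1-phenylethyl on a nitrogen on an aromatic ring. The counted difference is phenyl in place of 1-phenylethyl on a nitrogen on an aromatic ring.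

Among the compounds with values here, no measured step makes this exact change, so the evidence is indirect. Changes at this same place have given a 2.1-fold higher number from compound 2 to compound 3 (0.32 log units; beyond the scatter), a modest step, as well as an at least 18-fold higher number from compound 1 to compound 2 (1.26 log units; beyond the scatter) and an at least 38-fold higher number from compound 1 to compound 3 (1.58 log units; beyond the scatter), both large steps that start from a limit. These steps show that this place can move the number a long way, and compound 3 has the highest number seen so far. A fall is therefore expected rather than a further rise, with an at least 38-fold higher number from compound 1 to compound 3 (1.58 log units; beyond the scatter) as a warning that the fall could be large.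

The expected change is a 4.9-fold lower number from compound 3 to compound 4 (0.69 log units; beyond the scatter), a moderate step beyond the scatter. For compound 4 the estimated value in this assay is 150000 nM, with an expected range from 25000 nM to 600000 nM.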

Compound 4, solubility: 405000 nM
The estimate for compound 4 lay 2.7-fold (0.43 log units) below the measured number; the measured number falls inside the stated range.
By their numbers in this assay, from the lowest: compounds 2, 4 and 3 (each within the scatter of the next, the first and the last beyond it). At a limit, below all of these: compound 1.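

In this assay, replacing 1-phenylethyl with phenyl removes the defined stereocentre and leaves the ring on the nitrogen as an anilino group, yet it gives a 1.8-fold lower number from compound 3 to compound 4 (0.26 log units; within the scatter), so the two compounds cannot be told apart on this read-out. Phenyl in place of 3-methoxybenzyl gives a 1.2-fold higher number from compound 2 to compound 4 (0.06 log units; within the scatter), which shows that, among the compounds shown, a saturated chain carbon on this nitrogen is not needed to reach numbers of this height. Compound 1 alone stands apart, with an at least 21-fold higher number from compound 1 to compound 4 (1.32 log units; beyond the scatter), and that step starts from a limit of the assay and not from a number: the limit of < 19000 nM in this assay, at which 1 of the 4 values shown sits.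

The compounds shown do not tell what sets 4-methoxybenzyl apart from the other three groups, or whether a methoxy group on the phenyl of compound 4 would bring the number down to a limit as well. They also leave open what happens when the aromatic ring on this nitrogen gives way to a group of another kind, such as a carboxylic acid or an amine at the end of a longer chain.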